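The compounds below may be only part of what the source reports. "The series", "measured", "known", "first", "only" and "open" are said of these compounds alone.

Working notes on the series. All compounds share one core bearing a 3,4-dihydroxy-5-(hydroxymethyl)oxolan-2-yl group on the ring nitrogen and a five-membered aromatic group on a ring carbon. Compound 1 `Nc1nc(N)c2c(-c3cc4ccccc4o3)cn([C@@H]3O[C@H](CO)[C@@H](O)[C@H]3O)c2n1` carries 1-benzofuran-2-yl; in a functional assay on K562 cells (Homo sapiens), read by MTT assay, with a stated time of 72 h (a lower number here means a stronger inhibitor, a higher number a weaker inhibitor), compound 1 gives 18600 nM. Compound 3 `Cc1nc(N)c2c(-c3cc4ccccc4o3)cn([C@@H]3O[C@H](CO)[C@@H](O)[C@H]3O)c2n1` keeps the 1-benzofuran-2-yl and differs from compound 1 by methyl in place of amino on an aromatic carbon; in this assay compound 3 gives 15700 nM. The step of a 1.2-fold lower number from compound 1 to compound 3 (0.07 log units; within the scatter) is flat. Compound 2 `COc1ncnc2c1c(-c1cccs1)cn2[C@@H]1O[C@H](CO)[C@@H](O)[C@H]1O` carries thiophen-2-yl on a differently substituted core; in this assay compound 2 gives 70 nM. Among the three numbers compound 3 stands second highest: nearest to compound 1, within the scatter, and far from compound 2, well beyond it.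

Compound 4 `Cc1nc(N)c2c(-c3cccs3)cn([C@@H]3O[C@H](CO)[C@@H](O)[C@H]3O)c2n1` is the next step from compound 3: thiophen-2-yl in place of 1-benzofuran-2-yl on an aromatic carbon. Within the data shown here, no measured single-place step covers this exchange; the one measured step, a 1.2-fold lower number from compound 1 to compound 3 (0.07 log units; within the scatter), concerns another change and was flat. Among the measured compounds shown here, the sole thiophen-2-yl compound, compound 2, gives 70 nM, but it differs from compound 4 in the core as well, so that number cannot be assigned to the thiophen-2-yl alone. A lower number is therefore expected for compound 4, with wide uncertainty, as the expected step of a 3.9-fold lower number from compound 3 to compound 4 (0.59 log units; beyond the scatter). The estimate for compound 4 is 4000 nM, expected to fall between 600 nM and 16000 nM.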

Compound 4, half-maximal inhibitory concentration: > 20000 nM
Compound 4 gave a limit, no number (the forecaster's own chance of this, stated with the estimate: 5%); at least 5.0-fold (0.69 log units) between middle value and limit.
By their numbers in this assay, from the lowest: compound 2; then compounds 3 and 1 (each within the scatter of the next). At a limit, above all of these: compound 4.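

Compound 4 reaches only a limit in this assay, not a number: the limit of > 20000 nM in this assay, at which 1 of the 4 values shown sits. The step is an at least 1.2-fold higher number from compound 3 to compound 4 (0.10 log units; that floor lies within the scatter), so only a floor is known for this exchange, and that floor alone does not separate the two compounds. Among these compounds, what the earlier compounds could not show is that, on the core shared by compound 3 and compound 4, thiophen-2-yl in place of 1-benzofuran-2-yl on this aromatic carbon of the five-membered ring does not bring the number down, so thiophen-2-yl by itself gives no lower number here, while compound 2, at 70 nM, differs from compound 4 in more than one place and cannot be read against it.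

The compounds shown leave open how far the number on this core would move with a phenyl, a furan-2-yl or a simple amine on the same carbon. They also leave open what part of the low number of compound 2 comes from its core, which only 1-benzofuran-2-yl on that same core would settle.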